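A Methoxy Removed from a Disulfide Sulfoxide

The compounds below may be only part of what the source reports. "The series", "measured", "known", "first", "only" and "open" are said of these compounds alone.

Measured so far:
compound 1 `COc1ccc(CSSC=CC[S+]([O-])Cc2ccc(OC)cc2)cc1` gives 2100 nM
compound 2 `COc1ccc(CS/C=C/C[S+]([O-])Cc2ccc(OC)cc2)cc1` gives > 200000 nM, a limit of the assay
compound 3 `C=CCSS/C=C\C[S+]([O-])CCC` gives 23000 nM

In a functional assay on WHCO1 cells (Homo sapiens) for antiproliferative activity, read by MTT assay, with a stated time of 48 h (a lower number here means a stronger inhibitor, a higher number a weaker inhibitor), compound 1 gives the lowest of the two numbers. Compound 3 sits clearly higher, beyond the usual scatter. For compound 2 only a limit is reported (the limit of > 200000 nM in this assay, at which 1 of the 3 values shown sits). Compound 4 `COc1ccc(C[S+]([O-])CC=CSSCc2ccccc2)cc1` differs from compound 1 in one place: hydrogen in place of methoxy on an aromatic carbon. Among the compounds with values here, no two measured compounds differ in a single place, so the size of this step cannot be read from the measured values; a small move toward a higher number is expected, close to the scatter. For compound 4 the estimated value is 3500 nM, ranging from 1200 nM to 12000 nM. The expected step is a 1.7-fold higher number from compound 1 to compound 4 (0.22 log units; within the scatter).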

Compound 4, half-maximal inhibitory concentration: 3100 nM
For compound 4 the middle estimate is 1.1-fold (0.05 log units) above the measured one; the measured number falls inside the stated range.
By their numbers in this assay, from the lowest: compounds 1 and 4 (each within the scatter of the next); then compound 3. At a limit, above all of these: compound 2.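

In this assay, the change from 4-methoxyphenyl to phenyl comes to a 1.5-fold higher number from compound 1 to compound 4 (0.17 log units; within the scatter), so the two compounds cannot be told apart. Within the data shown here, this is the first comparison in the set that differs in a single place, and it shows that this methoxy is not needed to keep the activity of compound 1 in this assay. Nothing measured here gives a reason for this result.

As far as these compounds go, whether an amine or a carboxylic acid at this place on the ring would be tolerated remains open. So does the role of the methoxy on the other aromatic ring.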